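This account rests on a few compounds, and the source may have more. Where it says the series, first, only, none or still open, it means among the compounds named here.

Measured compounds:
compound 1 `NS(=O)(=O)c1ccc(N2N=C(c3ccc(Oc4ccccc4)cc3)CC2c2ccc(Cl)cc2)cc1`: 88000 nM
compound 2 `NS(=O)(=O)c1ccc(N2N=C(c3ccc(OCc4ccccc4)cc3)CC2c2ccc(F)cc2)cc1`: 90000 nM

In an ADME assay on Vero 76 cells (Chlorocebus sabaeus) for cytotoxicity, read by MTT assay, with a stated time of 96 h (on this read-out higher numbers stand for lower toxicity in this test and lower numbers for higher toxicity in this test), compound 1 gives 88000 nM and compound 2 gives 90000 nM; the two numbers lie within the usual scatter of each other, so compound 2 stands level with compound 1. Compound 3 `NS(=O)(=O)c1ccc(N2N=C(c3ccc(OCc4ccccc4)cc3)CC2c2ccccc2Cl)cc1` differs from compound 2 in one place: 2-chlorophenyl in place of 4-fluorophenyl on a saturated ring carbon. Within the data shown here, no step between measured compounds is available to size this change, and nothing in the two measured values suggests a move beyond the scatter in either direction. Compound 3 is therefore expected near 85000 nM, with a range of 40000 nM to 180000 nM, an estimated step of a 1.1-fold lower number from compound 2 to compound 3 (0.02 log units; within the scatter) that stays within the scatter.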

Compound 3, half-maximal cytotoxic concentration: 92000 nM
Compound 3: middle estimate off by 1.1-fold (0.03 log units), on the low side; measured number inside the range.
By their numbers in this assay, from the lowest: compounds 1, 2 and 3 (each within the scatter of the next).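

In this assay, the saturated ring carbon next to the ring nitrogen takes 2-chlorophenyl in place of 4-fluorophenyl with a 1.0-fold higher number from compound 2 to compound 3 (0.01 log units; within the scatter), so the two compounds stand level. Among these compounds, this is the first single-place step, and it gives a first reading for this position. Nothing at hand gives a reason for this result. All three compounds carry a substituted phenyl group at this carbon. From the compounds shown here alone, how an amine, a carboxylic acid or a longer chain there would read in this assay remains open.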